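Adding a second methyl beside the thiourea nitrogen

This account rests on a few compounds, and the source may have more. Where it says the series, first, only, none or still open, it means among the compounds named here.

Three thiourea compounds have been measured in an assay on CHO cells for displacement of a labelled ligand from transient receptor potential cation channel subfamily V member 1 (Rattus norvegicus); on this read-out lower numbers stand for stronger inhibition and higher numbers for weaker inhibition. Compound 1 `CCC(NC(=S)NCc1ccc(C(C)(C)C)cc1)c1ccc(NS(C)(=O)=O)c(F)c1` gives 230 nM in this assay. Compound 2 `CC(C)(C)c1ccc(CNC(=S)NC(C)(C)c2ccc(NS(C)(=O)=O)c(F)c2)cc1`, which carries two methyl groups on the carbon next to the thiourea nitrogen, gives 7700 nM in this assay. Compound 3 `COc1cc(C(C)NC(=S)NCc2ccc(C(C)(C)C)cc2)ccc1NS(C)(=O)=O` gives 67 nM in this assay, the lowest of the three numbers and therefore the strongest binding among them; its gaps to compound 1 and to compound 2 both lie beyond the usual scatter.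

Compound 4 `COc1cc(C(C)(C)NC(=S)NCc2ccc(C(C)(C)C)cc2)ccc1NS(C)(=O)=O` has not yet been measured. It differs from compound 3 in one place: methyl in place of hydrogen on a saturated chain carbon bound to an amide-type nitrogen, an aromatic carbon and a saturated chain carbon. The closest guide to this change is the pair of compound 1 and compound 2, which differ from each other in more than one place; what their two values show is that the compound with two methyl groups on that carbon has a far higher number. On that basis the step in this assay is expected to be large and in the weakening direction, well beyond the scatter, as a 22-fold higher number from compound 3 to compound 4 (1.35 log units; beyond the scatter). Compound 4 is estimated at 1500 nM, with a plausible range from 300 nM to 7000 nM.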

Compound 4, inhibition constant: 2890 nM
Beside the measured number, compound 4's estimate is 1.9-fold (0.28 log units) below it; measured number inside the range.
By their numbers in this assay, from the lowest: compound 3; then compound 1; then compound 4; then compound 2.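

In this assay, for the compounds shown here, the second methyl on this carbon can now be read on its own, with nothing else in the structure changing: methyl in place of hydrogen gives a 43-fold higher number from compound 3 to compound 4 (1.63 log units; beyond the scatter) and is a large step, something the earlier compounds could not show because no two of them differed in one place. The new compound also links the two compounds that carry two methyl groups on this carbon, and methoxy in place of fluoro on an aromatic carbon gives a 2.7-fold lower number from compound 2 to compound 4 (0.43 log units; beyond the scatter) and is a modest step, so with both methyl groups in place the change on the aromatic carbon still moves the number beyond the scatter. Nothing given here explains why the added methyl raises the number so sharply.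

The compounds shown leave open what happens on this carbon with a hydroxyl group or an amine in place of the remaining hydrogen or the added methyl. They also leave open how ethyl compares with methyl there, since compound 1 and compound 3 differ in more than that one place.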